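Removing one chloro from the dichlorophenyl amide of compound 2

The compounds below may be only part of what the source reports. "The series", "measured", "known", "first", "only" and "open" are said of these compounds alone.

Compound 1 `CCCCNC(=O)Oc1ccc(Cl)cc1C(=O)Nc1ccc(Cl)c(Cl)c1` gives 5.25 in a physicochemical assay for lipophilicity; on this read-out lower numbers stand for lower lipophilicity and higher numbers for higher lipophilicity. Among the compounds with values here, compound 2 `CCCCCCCCCCCNC(=O)Oc1ccc(Cl)cc1C(=O)Nc1ccc(Cl)c(Cl)c1` gives 8.17 in this assay and so stands highest of the two numbers measured; the only step recorded is a number 2.92 log units higher from compound 1 to compound 2 (beyond the scatter). Compound 3 `CCCCCCCCCCCNC(=O)Oc1ccc(Cl)cc1C(=O)Nc1ccc(Cl)cc1` has not yet been measured in this assay. It differs from compound 2 in one place: hydrogen in place of chloro on an aromatic carbon. Within the data shown here, no measured step covers this change: the single step on record, a number 2.92 log units higher from compound 1 to compound 2 (beyond the scatter), concerns heptyl in place of hydrogen on a saturated chain carbon and not the chlorinated ring of the amide, so the series itself gives no direct guide. With a single chlorine leaving and nothing entering, a step downward in this assay is expected, far smaller than the measured step. Compound 3 is therefore estimated at 7.5, within 7 to 8. The expected step is a number 0.67 log units lower from compound 2 to compound 3 (beyond the scatter).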

Compound 3, partition coefficient: 7.61
Compound 3: the middle estimate sits 0.11 log units below what was measured, within the range that was stated.
By their numbers in this assay, from the lowest: compound 1; then compound 3; then compound 2.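

The change from 3,4-dichlorophenyl to 4-chlorophenyl gives the series its first reading on the amide ring: in this assay the result is a number 0.56 log units lower from compound 2 to compound 3 (beyond the scatter). Substitution on this aromatic carbon, ortho to a chloro group, therefore registers on the read-out even though a single heavy atom leaves. The step is modest beside the large chain change, a number 2.92 log units higher from compound 1 to compound 2 (beyond the scatter), so the number of compound 3 remains governed far more by the chain than by this chloro in the pair comparisons available. No supporting measurement accounts for the size of the ring step.

On these data alone, it remains open whether the heptyl step repeats on the 4-chlorophenyl amide. Also open, as far as these compounds go, is how an amine or a carboxylic acid on this same aromatic carbon would compare with hydrogen.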